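A few compounds are considered here, and "the series" means these few. Any claim that something is new, unique, unknown or untested is made for them only; others in the source may bear on it.

Measured compounds:
compound 2 `O=C(CCCCCCn1cc(Nc2ncc(Cl)c(Nc3cccc(Cl)c3)n2)cn1)NO` — 840 nM
compound 1 `O=C(/C=C/c1ccc(Cn2cc(Nc3ncc(Cl)c(Nc4ccc(F)cc4)n3)cn2)cc1)NO` — 14100 nM

In an assay on isolated protein for inhibition of histone deacetylase 8 (Homo sapiens), read by fluorescence, with stated times of 5 min and 30 min (a lower number here means a stronger inhibitor, a higher number a weaker inhibitor), compound 2 gives 840 nM, the lower of the two numbers; compound 1 stands at 14100 nM, a gap beyond the scatter. Compound 3 `CNc1nc(Nc2cnn(CCCCCCC(=O)NO)c2)ncc1Cl` differs from compound 2 by methyl in place of 3-chlorophenyl on a nitrogen on an aromatic ring. Going by the values given here, no measured pair shows this change, so the step from compound 2 to compound 3 in this assay is uncertain; a moderate rise in the number, beyond the scatter, is expected. For compound 3 the estimate is 2500 nM, within 700 nM to 9000 nM, a step of a 3.0-fold higher number from compound 2 to compound 3 (0.47 log units; beyond the scatter).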

Compound 3, half-maximal inhibitory concentration: 4070 nM
For compound 3 the middle estimate is 1.6-fold (0.21 log units) below the measured one; low and high end bracket the measured number.
By their numbers in this assay, from the lowest: compound 2; then compound 3; then compound 1.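

In this assay, going by these compounds alone, methyl in place of 3-chlorophenyl on a nitrogen on an aromatic ring gives a 4.8-fold higher number from compound 2 to compound 3 (0.69 log units; beyond the scatter), the first single-place reading at this position. Inhibition remains measurable with the six-membered aromatic ring gone, but the 3-chlorophenyl compound keeps the lower number, beyond the scatter. Nothing available bears on the reason for this step.

The compounds shown do not divide the step between the chlorine and the ring. A plain phenyl or a cyclohexyl on this nitrogen would separate those two parts.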